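Homologating the basic side chain of compound 3

The compounds below may be only part of what the source reports. "The series", "measured", "known", "first", "only" and "open" are said of these compounds alone.

Among the three compounds measured in a functional assay on HT-29 cells (Homo sapiens) for antiproliferative activity, read by MTT assay, with a stated time of 72 h (on this read-out higher numbers stand for weaker inhibition and lower numbers for stronger inhibition), compound 3 `COc1cc2c(Oc3c(F)cc(NC(=O)NN4C(=O)CSC4c4c(F)cccc4F)cc3F)ccnc2cc1OCCCN1CCN(C)CC1` stands lowest with 150 nM. Compound 1 `COc1cc2c(Oc3c(F)cc(NC(=O)NN4C(=O)C(C)SC4c4c(F)cccc4F)cc3F)ccnc2cc1OCCCN1CCCC1` gives 670 nM, and compound 2 `COc1cc2c(Oc3c(F)cc(NC(=O)NN4C(=O)CSC4c4c(F)cccc4F)cc3F)ccnc2cc1OCCCN1CCc2sccc2C1` gives 1410 nM. Compound 1 and compound 3 differ in two places at once, so their values are only compared side by side. For the measured compounds named here, the one single-point step among the measured compounds is a 9.4-fold lower number from compound 2 to compound 3 (0.97 log units; beyond the scatter), which shows that the group at the end of the chain on the aromatic oxygen matters considerably.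

Compound 4 `CCN1CCN(CCCCOc2cc3nccc(Oc4c(F)cc(NC(=O)NN5C(=O)CSC5c5c(F)cccc5F)cc4F)c3cc2OC)CC1` is not yet measured. Its difference from compound 3 is (4-ethylpiperazin-1-yl)methyl in place of 4-methylpiperazin-1-yl on a saturated chain carbon, three bonds along the chain from an oxygen on an aromatic ring. This change keeps the same kind of basic ring and only lengthens the tether and the alkyl on the distal nitrogen, a much gentler change than the swap between compound 2 and compound 3. No measured pair tests exactly this homologation, so the expectation rests on the general sensitivity shown by a 9.4-fold lower number from compound 2 to compound 3 (0.97 log units; beyond the scatter) and on the small size of the present change: compound 4 is expected to stay close to compound 3, perhaps slightly weaker, with an estimated 1.7-fold higher number from compound 3 to compound 4 (0.22 log units; within the scatter). The estimate for compound 4 in this assay is 250 nM, with a range from 100 nM to 700 nM.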

Compound 4, half-maximal inhibitory concentration: 830 nM
The estimate for compound 4 lay 3.3-fold (0.52 log units) below the measured number; measured number above the stated range.
By their numbers in this assay, from the lowest: compound 3; then compounds 1, 4 and 2 (each within the scatter of the next, the first and the last beyond it).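

In this assay the piperazine ring alone does not carry the result, and a change that keeps this ring on a saturated chain carbon, three bonds along the chain from an oxygen on an aromatic ring, still registers clearly as a 5.5-fold higher number from compound 3 to compound 4 (0.74 log units; beyond the scatter) and lies beyond the scatter. The earlier step of a 9.4-fold lower number from compound 2 to compound 3 (0.97 log units; beyond the scatter) could have been read as favouring the piperazine ring in general, but the new comparison of a 1.7-fold lower number from compound 2 to compound 4 (0.23 log units; within the scatter) lies within the scatter, so compound 4 keeps none of that separation from compound 2 even though it retains the ring. No measurement is available here that would account for this sensitivity.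

The step from compound 3 to compound 4 alters the tether and the alkyl on the distal nitrogen together, so the compounds shown cannot assign the change to either one; 4-(4-methylpiperazin-1-yl)butyl and 3-(4-ethylpiperazin-1-yl)propyl would separate the two. On these data alone, it also remains open how a morpholine ring or a dimethylamino group at the end of the chain would compare with the 4-methylpiperazin-1-yl group of compound 3.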